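The compounds below may be only part of what the source reports. "The series", "measured", "known", "first", "only" and "open" are said of these compounds alone.

This piece follows one change, from compound 1 to compound 4, as seen in an ADME assay on microsomes from liver (Mus musculus) for metabolic stability, read by LC-MS, with a stated time of 30 min, tested at 1 uM; on this read-out higher numbers stand for a more stable compound and lower numbers for a less stable compound. Compound 1 `O=C(NCc1ccc(S(=O)(=O)N2CCCCC2)cc1)c1cc2ccncc2[nH]1` is one of three compounds with a measurement. In this assay compound 1 gives "below limit of detection" (no number reported), so no number stands for it. Compound 2 `CC(NC(=O)c1cc2cnccc2[nH]1)c1ccc(S(=O)(=O)N2CCCCC2)cc1` in this assay gives 0.65%, and compound 3 `O=C(NCc1ccc(S(=O)(=O)c2cccc(C(F)(F)F)c2)cc1)c1cnc2nccn2c1` in this assay gives 27%. Compound 1 thus sits at the very bottom of what the assay can report; compound 2 stands low as well, while compound 3 stands clearly higher than compound 2.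

Compound 4 `O=C(NCc1ccc(S(=O)(=O)N2CCCCC2)cc1)c1cc2cnccc2o1` differs from compound 1 in one place: a group of 9 heavy atoms (7 carbon, 1 nitrogen, 1 oxygen; one five-membered aromatic ring with 1 hetero atom, one six-membered aromatic ring with 1 hetero atom) in place of a group of 9 heavy atoms (7 carbon, 2 nitrogen; one five-membered aromatic ring with 1 hetero atom, one six-membered aromatic ring with 1 hetero atom), on a carbonyl carbon. The part that leaves carries a hydrogen-bond donor, the part that enters carries none. Among the compounds with values here, no measured pair shows this change, so its effect can only be judged from the three numbers at hand. Compound 1 gives "below limit of detection" (no number reported), and a step no larger than the usual scatter is expected in this assay, in either direction. Compound 4 is therefore estimated to remain at 3%, within a range from 0% to 15%, with a real chance that again no number is reported.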

Compound 4, percent of the compound remaining: 4.6%
For compound 4 the middle estimate is 1.6 percentage points below the measured one; measured number inside the range.
By their numbers in this assay, from the lowest: compounds 2 and 4 (each within the scatter of the next); then compound 3.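

In this assay, within the data shown here, compound 1 has no number, and no step to compound 4 can be read from it, even though compound 4 gives 4.6%. The compounds shown leave open whether exchanging the group with a hydrogen-bond donor for the one without changes stability at all. Nothing available offers an explanation for this result.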